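Cyclohexyl to 2-(trifluoromethyl)phenyl on the shared core

The source may report more compounds than this note shows. Statements on the series, on what has been measured and on what is new or still open speak of the compounds shown alone.

Values in an ADME assay on microsomes from liver (Homo sapiens) for metabolic stability (on this read-out higher numbers stand for a longer-lived compound and lower numbers for a shorter-lived compound), for the three measured compounds:
- compound 1 `CC#C[C@@H](Cc1nnn[nH]1)c1ccc(OCc2cc(Cl)c3scc(-c4ccccc4C)c3c2)cc1` gives 0.217 h
- compound 2 `CC#C[C@@H](Cc1nnn[nH]1)c1ccc(OCc2ccc3scc(C4CCCCC4)c3c2)cc1` gives 0.183 h
- compound 3 `CC#C[C@@H](Cc1nnn[nH]1)c1ccc(OCc2ccc3scc(-c4ccc(OCCC(C)(C)O)cc4C)c3c2)cc1` gives 0.95 h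

Compound 2 (0.183 h) and compound 1 (0.217 h) lie within the scatter of each other at the low end of the three numbers. Compound 3 (0.95 h) stands beyond the scatter from compound 2. Among the compounds with values here, no two measured compounds differ in one place only, so no measured step is available as a guide.

Compound 4 `CC#C[C@@H](Cc1nnn[nH]1)c1ccc(OCc2ccc3scc(-c4ccccc4C(F)(F)F)c3c2)cc1` carries 2-(trifluoromethyl)phenyl in place of cyclohexyl on an aromatic carbon of the five-membered aromatic ring with 1 sulfur (2-(trifluoromethyl)phenyl in place of cyclohexyl on an aromatic carbon). In this assay compound 1, which also has a six-membered aromatic ring on that carbon, gives 0.217 h and points to a number close to that of compound 2. Compound 3, with such a ring as well, gives 0.95 h and leaves room upward. Both differ from compound 4 elsewhere too, so the comparison is loose. A small upward step is expected (a 1.4-fold higher number from compound 2 to compound 4 (0.14 log units; within the scatter)), most likely within the scatter. The estimate for compound 4 is 0.25 h (expected range 0.12 h to 0.6 h).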

Compound 4, half-life: < 0.0667 h
Compound 4 ended at the assay's limit; the forecaster's own chance of this, stated with the estimate: 3%; middle value at least 3.7-fold (0.57 log units) from the limit.
By their numbers in this assay, from the lowest: compounds 2 and 1 (each within the scatter of the next); then compound 3. At a limit, below all of these: compound 4.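

In this assay compound 4 gives < 0.0667 h, which is a limit of the assay and not a number. Within the data shown here, on an aromatic carbon of the five-membered aromatic ring with 1 sulfur, two ring bonds from the ring sulfur, 2-(trifluoromethyl)phenyl in place of cyclohexyl gives the first one-place step, an at least 2.7-fold lower number from compound 2 to compound 4 (0.43 log units; beyond the scatter), so the half-life in this assay responds to the group at this carbon, and this change lowers it beyond the scatter. The step is a lower bound on the change and not its size, and the true gap stays unknown, with the bound set by: the limit of < 0.0667 h in this assay, at which 1 of the 4 values shown sits.

The compounds shown do not separate the part played by the trifluoromethyl group from that of the aromatic ring, and plain phenyl or 2-methylphenyl on the same core as compound 2 would give the one-place comparisons needed for that. Going by these compounds, it also stays open whether a non-aromatic ring on this carbon carrying an amine or a carboxylic acid would move the half-life away from the low end of the series.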